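The source may report more compounds than this note shows. Statements on the series, on what has been measured and on what is new or still open speak of the compounds shown alone.

Measured compounds:
compound 1 `CC(=O)Nc1cc(-c2c(Nc3cc[nH]n3)nc3cccnn23)nc(C)n1`: 200 ug/mL
compound 2 `CNc1cc(-c2c(Nc3cc[nH]n3)nc3cccnn23)nc(C)n1`: 7 ug/mL

In a physicochemical assay for solubility, in simulated intestinal fluid (on this read-out lower numbers stand for lower solubility and higher numbers for higher solubility), compound 2 gives 7 ug/mL, the lower of the two numbers, and compound 1 gives 200 ug/mL, the step between them being a 29-fold lower number from compound 1 to compound 2 (1.46 log units; beyond the scatter). Compound 3 `Cc1nc(Nc2cccnc2)cc(-c2c(Nc3cc[nH]n3)nc3cccnn23)n1` differs from compound 2 by pyridin-3-yl in place of methyl on a nitrogen on an aromatic ring. Going by the values given here, the only measured step changed a group on this same nitrogen, but no measured step puts a ring in place of a methyl there, so the direction rests on little. Compound 3 is expected to give 4 ug/mL, within 1 ug/mL to 20 ug/mL, a step of a 1.8-fold lower number from compound 2 to compound 3 (0.24 log units; within the scatter) that need not exceed the scatter.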

Compound 3, solubility: 1 ug/mL
The estimate for compound 3 lay 4.0-fold (0.60 log units) above the measured number, within the range that was stated.
By their numbers in this assay, from the lowest: compound 3; then compound 2; then compound 1.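

In this assay the nitrogen on an aromatic ring also accepts a ring, and pyridin-3-yl in place of methyl gives a 7.0-fold lower number from compound 2 to compound 3 (0.85 log units; beyond the scatter), a step the earlier pair did not show. Set against acetyl, pyridin-3-yl gives a 200-fold lower number from compound 1 to compound 3 (2.30 log units; beyond the scatter), so the three groups on this nitrogen run from acetyl, highest, through methyl to pyridin-3-yl, lowest. Nothing given here accounts for these steps. The compounds shown leave open how a phenyl ring, a morpholine or a longer chain ending in an amine would read on this nitrogen.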